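Benzyl in Place of a Silyl Chain at the Amine

This account rests on a few compounds, and the source may have more. Where it says the series, first, only, none or still open, it means among the compounds named here.

Three compounds sharing one core have been examined in a functional assay on HEK293 cells for agonist activity at Toll-like receptor 8 (Homo sapiens), read by reporter gene assay; on this read-out higher numbers stand for an effect only at larger amounts of compound and lower numbers for an effect already at smaller amounts. Compound 1 `Cc1ncc(CO)c2c(Nc3cnccn3)c(NC(C)(C)C)oc12` is recorded as "not active" (no number reported). Compound 2 `Cc1ncc(CO)c2c(Nc3ccccn3)c(NC[Si](C)(C)C)oc12` gives 4990 nM in this assay, the lower of the two numbers recorded, while compound 3 `Cc1ncc(CO)c2c(Nc3cnccn3)c(NC3CCCCC3)oc12` gives 10600 nM, a gap beyond the usual scatter. Compound 4 `Cc1ncc(CO)c2c(Nc3ccccn3)c(NCc3ccccc3)oc12` has not yet been measured in this assay. It differs from compound 2 in one place: a group of 6 heavy atoms (6 carbon; one six-membered aromatic ring of carbon only) in place of a group of 4 heavy atoms (3 carbon, 1 silicon; no ring), on a saturated chain carbon bound to a nitrogen on an aromatic ring. Among the measured compounds shown here, no step between two measured compounds bears on this change, so the expectation rests only on the spread seen so far. Compound 4 is expected to give 3000 nM in this assay, within a range from 800 nM to 12000 nM. The estimated step is a 1.7-fold lower number from compound 2 to compound 4 (0.22 log units; within the scatter), a modest move toward a lower number that may not exceed the scatter.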

Compound 4, half-maximal effective concentration: 4910 nM
Estimate against measurement, compound 4: 1.6-fold (0.21 log units) below; the measured number falls inside the stated range.
By their numbers in this assay, from the lowest: compounds 4 and 2 (each within the scatter of the next); then compound 3.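

Putting phenyl in place of the silicon-bearing group, on a saturated chain carbon bound to a nitrogen on an aromatic ring, gives a 1.0-fold lower number from compound 2 to compound 4 (0.01 log units; within the scatter) in this assay and so leaves the two compounds indistinguishable. Silicon is therefore not needed at this place for a number of this size, since compound 4 carries none. Nothing at hand explains why the two groups read alike.

As far as these compounds go, whether a methoxy group or an amine on the phenyl ring, or a longer chain ending in phenyl, would shift the number remains open. So does whether phenyl would read the same alongside the other aromatic amine carried by compound 3.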